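This account rests on a few compounds, and the source may have more. Where it says the series, first, only, none or still open, it means among the compounds named here.

Compound 1 `O=C(/C(=C\c1ccc(O)cc1O)Sc1ccc(Br)cc1)c1ccc(Cl)cc1`: 50000 nM in a functional assay on DU-145 cells (Homo sapiens) for inhibition, read by trypan blue exclusion, with a stated time of 96 h; on this read-out higher numbers stand for weaker inhibition of growth and lower numbers for stronger inhibition of growth
Compound 2 `Cc1cc(C)cc(/C=C(/Sc2ccc(Br)cc2)C(=O)c2ccc(Cl)cc2)c1`: 10000 nM
Compound 3 `CN(C)c1ccc(/C=C(/Sc2ccc(Br)cc2)C(=O)c2ccc(Cl)cc2)cc1`: > 100000 nM, a limit of the assay rather than a number

Compound 3 thus stands at the limit of > 100000 nM in this assay, at which 1 of the 3 values shown sits, and its result in this assay is a limit only, so it supplies no number to work from. The measured steps of a 5.0-fold lower number from compound 1 to compound 2 (0.70 log units; beyond the scatter), an at least 2.0-fold higher number from compound 1 to compound 3 (0.30 log units; that floor lies within the scatter) and an at least 10-fold higher number from compound 2 to compound 3 (1.00 log units; beyond the scatter) all change the aryl group on the double-bonded chain carbon and leave the sulfur untouched, so none of them bears on the change to compound 4 `CN(C)c1ccc(/C=C(/SCc2ccc(F)cc2)C(=O)c2ccc(Cl)cc2)cc1`, which is 4-fluorobenzyl in place of 4-bromophenyl on a sulfur. Among the measured compounds shown here, with no step touching the sulfur, no direction beyond the scatter can be expected. Compound 4 is therefore expected to give 100000 nM, between 20000 nM and 300000 nM, with a limit again likely. The expected step is a number no higher from compound 3 to compound 4 (the limit leaves the size open).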

Compound 4, concentration for 50% growth inhibition: 50000 nM
Compound 4: the middle estimate sits 2.0-fold (0.30 log units) above what was measured; measured number inside the range.
By their numbers in this assay, from the lowest: compound 2; then compounds 1 and 4 (each within the scatter of the next). At a limit, above all of these: compound 3.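

In this assay, 4-fluorobenzyl in place of 4-bromophenyl on a sulfur gives an at least 2.0-fold lower number from compound 3 to compound 4 (0.30 log units; that floor lies within the scatter). The group on the sulfur can thus be changed with a number, rather than a limit, as the result, while the 4-(dimethylamino)phenyl group stays in place. The true size of the step remains unknown, since the value for compound 3 is a limit only: the limit of > 100000 nM in this assay, at which 1 of the 4 values shown sits.

The ring halogen and the benzyl methylene change together here, so a 4-bromobenzyl or 4-fluorophenyl group on the sulfur would be needed to separate them. On these data alone, whether 4-fluorobenzyl acts alike with the 3,5-dimethylphenyl group of compound 2 also stays open.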